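A few compounds are considered here, and "the series" means these few. Any claim that something is new, unique, unknown or untested is made for them only; others in the source may bear on it.

Working notes on the series, read in a functional assay on HepG2 cells (Homo sapiens) for cytotoxicity, read by MTT assay, with a stated time of 48 h; a lower number here means a stronger inhibitor, a higher number a weaker inhibitor. Compound 1 `NNC(=O)CSc1nnc(-c2ccncc2)o1` gives 3260 nM. Compound 2 `O=C(CSc1nnc(-c2ccncc2)o1)N/N=C/c1ccc(Br)cc1` gives 18600 nM, a number well beyond the scatter from that of compound 1. Compound 3 `O=C(CSc1nnc(-c2ccncc2)o1)N/N=C/c1ccc([N+](=O)[O-])cc1` gives 17900 nM, and this places compound 2 level with it: nitro in place of bromo on an aromatic carbon gave a 1.0-fold lower number from compound 2 to compound 3 (0.02 log units; within the scatter).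

The next compound to be read is compound 4 `COc1ccc(/C=N/NC(=O)CSc2nnc(-c3ccncc3)o2)cc1`. Its change from compound 2 is methoxy in place of bromo on an aromatic carbon, para to a large group. Among the measured compounds shown here, only one measured step bears on this position, a 1.0-fold lower number from compound 2 to compound 3 (0.02 log units; within the scatter), and a single step at one position is thin evidence. For the measured compounds named here, no measured compound yet carries methoxy. No shift beyond the scatter in this assay is therefore expected, in either direction. The estimated step is a 1.1-fold lower number from compound 2 to compound 4 (0.04 log units; within the scatter). The estimate for compound 4 is 17000 nM, with an expected range from 8000 nM to 35000 nM.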

Compound 4, half-maximal inhibitory concentration: 15800 nM
Compound 4: middle estimate off by 1.1-fold (0.03 log units), on the high side; the range from low to high includes it.
By their numbers in this assay, from the lowest: compound 1; then compounds 4, 3 and 2 (each within the scatter of the next).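

In this assay, this position now carries three different groups without a shift beyond the scatter: methoxy in place of bromo gives a 1.2-fold lower number from compound 2 to compound 4 (0.07 log units; within the scatter), and methoxy in place of nitro gives a 1.1-fold lower number from compound 3 to compound 4 (0.05 log units; within the scatter). The earlier compounds shown here offered a single exchange here, whereas the flat reading now rests on bromo, nitro and methoxy, and the change from 4-bromophenyl to 4-methoxyphenyl adds a heavy atom and a hydrogen-bond acceptor with no shift beyond the scatter. Nothing on hand offers a reason for this flat reading.

As far as these compounds go, whether it holds for an amine, a carboxylic acid or a longer chain such as ethoxy at this position remains open. Also open, from the compounds shown here alone, is how a group reads elsewhere on the aromatic ring, since all three sit para to a large group.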